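The source may report more compounds than this note shows. Statements on the series, on what has been measured and on what is new or still open speak of the compounds shown alone.

Working notes on the series. In a functional assay on the whole organism (strain Wistar) for inhibition, with Rattus norvegicus as the target, read by paw edema, with stated times of 30 min and 60 min, at a dose of 50 mg/kg by the oral route (a lower number here means less inhibition, a higher number more inhibition at the dose given (going by the name of the read-out)), compound 2 `Fc1ccc(C2=NN(c3ccccc3)C(c3cn(-c4ccccc4)nc3-c3ccc(Cl)c(Cl)c3)C2)cc1` gives 55.7% and stands in the middle of the three numbers, with every gap to the other two within the usual scatter. Compound 1 `CC(=O)N1N=C(c2ccc(C)cc2)CC1c1cn(-c2ccccc2)nc1-c1ccc(Cl)c(Cl)c1` gives 59.5% and compound 3 `Clc1ccc(C2=NN(c3ccccc3)C(c3cn(-c4ccccc4)nc3-c3ccc(Cl)c(Cl)c3)C2)cc1` gives 53.4% in this assay. For the measured compounds named here, the single measured step, a number 2.3 percentage points lower from compound 2 to compound 3 (within the scatter), changes a different part of the molecule and stays within the scatter. Compound 4 `Fc1ccc(C2=NNC(c3cn(-c4ccccc4)nc3-c3ccc(Cl)c(Cl)c3)C2)cc1` differs from compound 2 as follows: hydrogen in place of phenyl on an amine nitrogen in a ring. Going by the values given here, no measured step touches the amine nitrogen in the ring, so nothing here points to a move beyond the scatter in either direction. Compound 4 is therefore expected near 53%, in the range 40% to 64%. The expected step is a number 2.7 percentage points lower from compound 2 to compound 4 (within the scatter), essentially none.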

Compound 4, a percentage reported as inhibition, in the whole organism at one dose (the size of the read-out at that dose, not a potency): 40.5%
Beside the measured number, compound 4's estimate is 12.5 percentage points above it; the range from low to high includes it.
By their numbers in this assay, from the lowest: compound 4; then compounds 3, 2 and 1 (each within the scatter of the next).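

In this assay, for the compounds shown here, hydrogen in place of phenyl on the amine nitrogen in the ring gives a number 15.2 percentage points lower from compound 2 to compound 4 (beyond the scatter), the first single change to move the number beyond the scatter. The phenyl on this nitrogen therefore counts for the read-out at the dose given, which the chloro-for-fluoro step could not show. Nothing available explains the loss.

As far as these compounds go, whether phenyl itself is needed stays open, since a methyl or benzyl group on this nitrogen would be required to tell. Compound 1 carries acetyl there but differs from compound 2 in a second place, so it cannot settle this.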